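The source may report more compounds than this note shows. Statements on the series, on what has been measured and on what is new or still open speak of the compounds shown alone.

Measured in a functional assay on A549 cells (Homo sapiens) for antiproliferative activity, read by sulforhodamine B assay, with a stated time of 3 days; a lower number here means a stronger inhibitor of growth, a higher number a weaker inhibitor of growth:
- compound 1 `O=C(Nc1cccc(Nc2ncc(F)c(Nc3ccc(F)cc3)n2)c1)c1cnccn1` gives 10300 nM
- compound 2 `O=C(c1cccc(Nc2ncc(F)c(Nc3ccc(F)cc3)n2)c1)N1CCCCC1` gives 13200 nM
- compound 3 `O=C(Nc1cc(Cl)cc(Cl)c1)c1cccc(Nc2ncc(F)c(Nc3ccc(F)cc3)n2)c1` gives 17500 nM

Compound 3 stands level with the other two, with a 1.3-fold higher number from compound 2 to compound 3 (0.12 log units; within the scatter) and a 1.7-fold higher number from compound 1 to compound 3 (0.23 log units; within the scatter). Compound 4 `O=C(NCCO)c1cccc(Nc2ncc(F)c(Nc3ccc(F)cc3)n2)c1` has 2-hydroxyethyl in place of 3,5-dichlorophenyl on an amide-type nitrogen, and the count reads (2-hydroxyethyl in place of 3,5-dichlorophenyl on an amide-type nitrogen). The nearest measured change, (3,5-dichlorophenyl)amino in place of piperidin-1-yl on a carbonyl carbon, is a 1.3-fold higher number from compound 2 to compound 3 (0.12 log units; within the scatter). The other measured change of this kind is a 1.3-fold higher number from compound 1 to compound 2 (0.11 log units; within the scatter). For the measured compounds named here, no measured compound carries 2-hydroxyethyl, so the range stays wide. In this assay no shift beyond the scatter is expected, and the expected change is a 1.2-fold lower number from compound 3 to compound 4 (0.07 log units; within the scatter). The estimate for compound 4 is 15000 nM, with an expected range of 5000 nM to 40000 nM.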

Compound 4, concentration for 50% growth inhibition: 11900 nM
Compound 4: the middle estimate sits 1.3-fold (0.10 log units) above what was measured, within the range that was stated.
By their numbers in this assay, from the lowest: compounds 1, 4, 2 and 3 (each within the scatter of the next).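

In this assay, 2-hydroxyethyl in place of 3,5-dichlorophenyl on the amide-type nitrogen removes the aromatic ring and still stays within the scatter (a 1.5-fold lower number from compound 3 to compound 4 (0.17 log units; within the scatter)), so at this place a ringless chain with a hydrogen-bond donor and acceptor reads like a dichlorinated aryl group. Compound 4 is also level with the piperidine amide (a 1.1-fold lower number from compound 2 to compound 4 (0.05 log units; within the scatter)) and the pyrazine compound (a 1.2-fold higher number from compound 1 to compound 4 (0.06 log units; within the scatter)), which leaves all four compounds undifferentiated. No accompanying measurement bears on this flat reading.

From the compounds shown here alone, whether any group here moves the number beyond the scatter stays open. A terminal amine, a carboxylic acid or a longer chain such as 4-hydroxybutyl on the same nitrogen would test this.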